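The source may report more compounds than this note shows. Statements on the series, on what has been measured and on what is new or still open speak of the compounds shown alone.

Working notes on the series, read in an ADME assay on HEp-2 cells (Homo sapiens) for cytotoxicity, read by MTT assay, with a stated time of 72 h; a lower number here means a stronger inhibitor, a higher number a weaker inhibitor.

Compound 1 (`C=CCOc1cc(C2=C(c3cc(OC)c(OC)c(OC)c3)C(=O)C(O)C2)ccc1OC`) gives > 100 ug/mL in this assay and this is a limit, not a number. Compound 2 (`COC(=O)c1cc(C2=C(c3cc(OC)c(OC)c(OC)c3)C(=O)CC2O[SiH2]C(C)(C)C)ccc1OC`) gives > 100 ug/mL and this too is a limit. For the measured compounds named here, no compound therefore has a numerical value yet, and no step between measured compounds is available to calibrate a change. The whole picture so far is the limit of > 100 ug/mL in this assay, at which 2 of the 2 values shown sit, and nothing more.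

Compound 3 (`COc1ccc(C2=C(c3cc(OC)c(OC)c(OC)c3)C(=O)C(O)C2)cc1OC(C)C`) keeps the core of compound 1 and changes one group: allyloxy to isopropoxy, that is, isopropyl in place of allyl on an oxygen on an aromatic ring. Nothing in the two measured compounds points to a direction for this swap. The expectation therefore rests on compound 1 with its limit of > 100 ug/mL and assumes no shift beyond the scatter. The expected move is a step that the limit leaves unreadable from compound 1 to compound 3 with neither direction favoured. For compound 3 the estimated value is 120 ug/mL with an expected range from 50 ug/mL to 250 ug/mL and a report as a limit is thought likely.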

Compound 3, half-maximal inhibitory concentration: > 100 ug/mL
Compound 3 gave a limit, no number; the forecaster's own chance of this, stated with the estimate: 75%; the middle value is on the limit's open side.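

For the compounds shown here, compound 1 and compound 3 both stand as limits, so no step between them can be read. The compounds shown leave open whether any member of the series reaches a numerical value in this assay, and whether isopropyl in place of allyl changes it at all. The whole picture remains: the limit of > 100 ug/mL in this assay, at which 3 of the 3 values shown sit.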